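Halogen swap on the aryl amine of a shared core

The source may report more compounds than this note shows. Statements on the series, on what has been measured and on what is new or still open speak of the compounds shown alone.

Measured compounds:
- compound 1, `COc1ccc(Nc2c(-c3ccc4[nH]nc(C)c4c3)nc3cnc(N4CCN(C)CC4)cn23)cc1`: 0%
- compound 2, `Cc1n[nH]c2ccc(-c3nc4cnc(N5CCN(C)CC5)cn4c3Nc3ccc(Cl)cc3F)cc12`: "not determined" (no result reported)

The two measured compounds share the same core and differ only in the aryl group on the ring nitrogen. In a functional assay on CWR22R cells (Homo sapiens) for inhibition, with a stated time of 120 h, tested at 10 uM (a lower number here means less inhibition, a higher number more inhibition at the concentration tested (going by the name of the read-out)), compound 1 gives 0%, which is no inhibition at the concentration tested. In this assay compound 2 gives "not determined" (no result reported), that is, no single number, so where it stands against compound 1 cannot be said.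

Compound 3, `Cc1n[nH]c2ccc(-c3nc4cnc(N5CCN(C)CC5)cn4c3Nc3ccc(F)cc3Br)cc12`, is to be measured in this assay. It differs from compound 2 by a change on the aryl amine, (2-bromo-4-fluorophenyl in place of 4-chloro-2-fluorophenyl on a nitrogen on an aromatic ring). For the measured compounds named here, no measured pair shows how a halogen swap of this kind moves the read-out, so no step size can be drawn from the data; the only anchor is compound 1, which sits at no inhibition. In this assay compound 3 is expected to give about 5%, estimated to fall between 0% and 25%, resting on compound 1 giving 0% and on the absence of any step that points to more inhibition.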

Compound 3, a percentage reported as inhibition, at one concentration (the size of the read-out at that concentration, not a potency): 4.41%
Compound 3: the middle estimate sits 0.6 percentage points above what was measured; the measured number falls inside the stated range.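

Placing 2-bromo-4-fluorophenyl instead of 4-methoxyphenyl on a nitrogen on an aromatic ring gives, in this assay, a number 4.4 percentage points higher from compound 1 to compound 3 (within the scatter) and so the two aryl groups cannot be told apart in this read-out at the single concentration tested. For the compounds shown here, this is the first number for a halogen-bearing aryl amine on the shared core, and it shows that exchanging the methoxy-bearing ring for this dihalogenated ring leaves the result within the usual variation of the measurement, while the step between compound 2 and compound 3 cannot be read, since compound 2 has no number. Nothing measured alongside these results speaks to what lies behind them.

As far as these compounds go, whether the 4-chloro-2-fluorophenyl group of compound 2 would behave like the 2-bromo-4-fluorophenyl group of compound 3 remains open. Also open, from the compounds shown here alone, is whether a different kind of substituent at this place, such as an aryl ring carrying a carboxylic acid or an amine, or a longer alkyl chain in place of the aryl ring, would give a result that stands apart from these compounds in this assay at all.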